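A few compounds are considered here, and "the series" means these few. Any claim that something is new, unique, unknown or untested is made for them only; others in the source may bear on it.

In an ADME assay on HEK293 cells (Homo sapiens) for cytotoxicity, read by CCK-8 assay, with a stated time of 48 h; on this read-out lower numbers stand for stronger inhibition and higher numbers for weaker inhibition:

Compound 1 `COc1ccc(/C=C\c2cc(OC)c(OC)c(OC)c2)cc1OCc1ccc(CNC(C)(C)C(=O)O)cc1`: > 50000 nM (limit)
Compound 2 `COc1ccc(/C=C\c2cc(OC)c(OC)c(OC)c2)cc1OCc1ccc(CN2CCCCC2C(=O)O)cc1`: > 50000 nM (limit)
Compound 3 `COc1ccc(/C=C\c2cc(OC)c(OC)c(OC)c2)cc1OCc1ccc(CN2CC[C@@H](O)C2)cc1`: > 50000 nM (limit)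

Compound 3 gives > 50000 nM, a limit and not a number. It shares this with the other two compounds: the limit of > 50000 nM in this assay, at which 3 of the 3 values shown sit.

The next change gives compound 4 `COc1ccc(/C=C\c2cc(OC)c(OC)c(OC)c2)cc1OCc1ccc(CN[C@H](C(=O)O)[C@@H](C)O)cc1`: (1-carboxy-2-hydroxypropyl)amino in place of 3-hydroxypyrrolidin-1-yl on a saturated chain carbon bound to an aromatic carbon. In words, (1-carboxy-2-hydroxypropyl)amino stands in place of 3-hydroxypyrrolidin-1-yl on a saturated chain carbon bound to an aromatic carbon.

The nearest measured comparisons are a step that the two limits leave unreadable from compound 1 to compound 3 and a step that the two limits leave unreadable from compound 2 to compound 3. Each also swaps a carboxy-bearing amine group with 3-hydroxypyrrolidin-1-yl, and neither has a readable size. No step beyond the scatter is therefore expected, and the expected change is a number no higher from compound 3 to compound 4 (the limit leaves the size open).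

The estimate for compound 4 is 50000 nM, with an expected range of 25000 nM to 100000 nM, and a report as a limit is again likely.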

Compound 4, half-maximal inhibitory concentration: > 50000 nM
Compound 4: only a limit was reported; the forecaster's own chance of this, stated with the estimate: 88%; the middle value sits exactly at the limit.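

Among these compounds, compound 4 is reported only as a limit in this assay, so no step to it from compound 1, compound 2 or compound 3 can be read: the limit of > 50000 nM in this assay, at which 4 of the 4 values shown sit. The size of any difference among these four compounds in this assay stays open.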